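Changing the aryl group on the sulfonyl sulfur

This account rests on a few compounds, and the source may have more. Where it says the series, first, only, none or still open, it means among the compounds named here.

Compound 1 `CC(=O)Nc1ccc(S(=O)(=O)NNC(=O)c2cccnc2Nc2ccc(Cl)cc2)cc1`: in a functional assay on SR cells (Homo sapiens) for antiproliferative activity (a higher number here means a weaker inhibitor of growth, a lower number a stronger inhibitor of growth), compound 1 gives > 100000 nM, which is a limit of the assay and not a number.
Compound 2 `O=C(NNS(=O)(=O)c1ccc(F)cc1)c1cccnc1Nc1ccc(Cl)cc1Cl`: in this assay compound 2 gives 67600 nM.

Going by these compounds, compound 1 therefore stands only at the limit of this assay (the limit of > 100000 nM in this assay, at which 1 of the 2 values shown sits), so its true value is unknown. Within the data shown here, compound 2 is the only member with a measured number, and that number marks a weak inhibitor of growth. Among the measured compounds shown here, no step between two measured compounds that differ in one place is available.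

Compound 3 `O=C(NNS(=O)(=O)c1ccc(Cl)cc1Cl)c1cccnc1Nc1ccc(Cl)cc1` differs from compound 1 by 2,4-dichlorophenyl in place of 4-acetamidophenyl on a sulfonyl sulfur. For the measured compounds named here, with no measured step to lean on, the expected step from compound 1 to compound 3 in this assay is an at least 1.6-fold lower number from compound 1 to compound 3 (0.22 log units; that floor lies within the scatter), a modest move toward a stronger inhibitor, and a further limit reading is quite possible. Compound 3 is estimated at 60000 nM, with a range from 15000 nM to 200000 nM.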

Compound 3, concentration for total growth inhibition: 38000 nM
Compound 3: the middle estimate sits 1.6-fold (0.20 log units) above what was measured; low and high end bracket the measured number.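

In this assay, exchanging the 4-acetamidophenyl on a sulfonyl sulfur for 2,4-dichlorophenyl gives an at least 2.6-fold lower number from compound 1 to compound 3 (0.42 log units; beyond the scatter). Among these compounds, this is the first sign that the aryl group at this position can change the read-out by more than the usual scatter, and compound 3 gives a measured 38000 nM in a series where compound 1 gave no number. The true size of this step stays unknown, and only its floor can be read, because the value of compound 1 is a limit of the assay: the limit of > 100000 nM in this assay, at which 1 of the 3 values shown sits.

Among the compounds shown here, the single swap cannot show whether the shift comes from losing the acetamide or from gaining the two chlorines, and a plain phenyl ring or a ring bearing one chlorine would help separate the two. Going by these compounds, whether an amine on the ring or a simple methyl group on the sulfur would fit this trend also remains open.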